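Three Amide Variants Seen, a Fourth One Estimated

The source may report more compounds than this note shows. Statements on the series, on what has been measured and on what is new or still open speak of the compounds shown alone.

Measured compounds:
- compound 1, `Cc1nc(S(C)(=O)=O)ccc1Oc1ncnc(OC2CCN(C(=O)OC3(C(F)(F)F)CCC3)CC2)c1F`, gives 14.3 nM
- compound 2, `CCC(F)(F)C(=O)N1CCC(Oc2ncnc(Oc3ccc(S(C)(=O)=O)nc3C)c2F)CC1`, gives 17.4 nM
- compound 3, `Cc1nc(S(C)(=O)=O)ccc1Oc1ncnc(OC2CCN(C(=O)C3(F)CCC3)CC2)c1F`, gives 24.7 nM

All three were tested in a functional assay on isolated protein for inhibition of Glucose-dependent insulinotropic receptor (Homo sapiens), read by HTRF and cAMP accumulation; on this read-out lower numbers stand for an effect already at smaller amounts and higher numbers for an effect only at larger amounts of compound. Compound 1 has the lowest of the three numbers, but its nearest neighbour is compound 2 with a 1.2-fold higher number from compound 1 to compound 2 (0.09 log units; within the scatter), and the furthest is compound 3 with a 1.7-fold higher number from compound 1 to compound 3 (0.24 log units; within the scatter), so none of the three can be set apart from the others. The step of a 1.4-fold higher number from compound 2 to compound 3 (0.15 log units; within the scatter) is likewise within the scatter.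

Compound 4, `Cc1nc(S(C)(=O)=O)ccc1Oc1ncnc(OC2CCN(C(=O)C3(C)CC3)CC2)c1F`, has not yet been measured. It differs from compound 1 by a group of 4 heavy atoms (4 carbon; one three-membered non-aromatic ring of carbon only) in place of a group of 9 heavy atoms (5 carbon, 1 oxygen, 3 fluorine; one four-membered non-aromatic ring of carbon only), on a carbonyl carbon. All three measured steps touch the same carbonyl carbon and swap groups of this kind, and none of them moved the number beyond the scatter. The step from compound 1 to compound 4 is therefore expected to be small as well, with no direction that can be told apart from the scatter, and the expected step is a 1.7-fold higher number from compound 1 to compound 4 (0.24 log units; within the scatter). For compound 4 the estimated value in this assay is 25 nM, within a range from 10 nM to 60 nM.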

Compound 4, half-maximal effective concentration: 761 nM
Estimate against measurement, compound 4: 30-fold (1.48 log units) below; the measured number lies above the stated range.
By their numbers in this assay, from the lowest: compounds 1, 2 and 3 (each within the scatter of the next); then compound 4.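

For the compounds shown here, the carbonyl carbon tolerates less than the earlier compounds suggested: with 1-methylcyclopropyl in place, the number in this assay climbs, with a 53-fold higher number from compound 1 to compound 4 (1.73 log units; beyond the scatter), a 44-fold higher number from compound 2 to compound 4 (1.64 log units; beyond the scatter) and a 31-fold higher number from compound 3 to compound 4 (1.49 log units; beyond the scatter). Going by these compounds alone, the three earlier groups are quite different from one another, one even lacking a ring, yet all carry fluorine, whereas 1-methylcyclopropyl has no fluorine and is the only one with a three-membered ring. Nothing available explains the jump, so this contrast remains an observation about four compounds and not a cause.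

From the compounds shown here alone, it remains open whether the loss of fluorine or the three-membered ring goes with the higher number. A 1-methylcyclobutyl group would keep the four-membered ring without fluorine, and a 1-fluorocyclopropyl group would keep the three-membered ring with fluorine, so these two could separate the two features.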